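The source may hold more compounds than are shown below. What is called first, only, known or untested is meant among the compounds shown, and "the series" means these compounds.

Of the compounds shown here, three that share one core have been tested in a functional assay on MDA-MB-231 cells (Homo sapiens) for inhibition, read by sulforhodamine B assay, tested at 10 uM; a lower number here means less inhibition, a higher number more inhibition at the concentration tested (going by the name of the read-out). Compound 1 `CN1CCN(c2ccc(C3=NNC(c4ccc(N(C)C)cc4)C3)cc2)CC1` gives 11.4% in this assay. Compound 2 `CN(C)c1ccc(C2CC(c3ccc(-n4ccnc4)cc3)=NN2)cc1`, which carries 1H-imidazol-1-yl in place of 4-methylpiperazin-1-yl on an aromatic carbon, gives 7.6%, and the step of a number 3.8 percentage points lower from compound 1 to compound 2 (within the scatter) lies within the scatter. Compound 3 `CN1CCN(c2ccc(C3=NN(C(=O)CCCl)C(c4ccc(N(C)C)cc4)C3)cc2)CC1`, which carries (2-chloroethyl)carbonyl in place of hydrogen on an amine nitrogen in a ring, gives 2.4%, and the step of a number 9 percentage points lower from compound 1 to compound 3 (within the scatter) is also within the scatter. All three numbers thus fall within the scatter of one another, and compound 3 is not set apart from compound 1 or compound 2 by its number.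

Compound 4 `CN1CCN(c2ccc(C3=NN(C(=O)c4ccc(C(F)(F)F)cc4)C(c4ccc(N(C)C)cc4)C3)cc2)CC1` differs from compound 3 in one place: 4-(trifluoromethyl)phenyl in place of 2-chloroethyl on a carbonyl carbon. Among the measured compounds shown here, the only measured step that touches this carbonyl position is a number 9 percentage points lower from compound 1 to compound 3 (within the scatter), and it stayed within the scatter; no measured pair exchanges one group on the carbonyl carbon for another. A step of a number 2.6 percentage points higher from compound 3 to compound 4 (within the scatter) is therefore expected, nothing beyond the scatter. Compound 4 is estimated to give 5%, with a range from -8% to 18%.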

Compound 4, a percentage reported as inhibition, at one concentration (the size of the read-out at that concentration, not a potency): 55.4%
Compound 4: the middle estimate sits 50.4 percentage points below what was measured, and the stated range ends below it.
By their numbers in this assay, from the lowest: compounds 3, 2 and 1 (each within the scatter of the next); then compound 4.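

Among the compounds shown here, at the carbonyl carbon, the group carried now matters in this assay: with 4-(trifluoromethyl)phenyl in place of 2-chloroethyl, the result is a number 53 percentage points higher from compound 3 to compound 4 (beyond the scatter), the first change in this set to go beyond the scatter. A carbonyl on the ring nitrogen is not enough on its own, as the result is a number 9 percentage points lower from compound 1 to compound 3 (within the scatter), whereas the aromatic version gives a number 44 percentage points higher from compound 1 to compound 4 (beyond the scatter). Nothing measured here accounts for this jump.

Going by these compounds, it remains open whether the higher number goes with the aromatic ring or with the trifluoromethyl on it, a question that a plain phenyl or a 4-methoxyphenyl on the same carbonyl could help to separate. On these data alone, it is also open whether a longer alkyl chain there would behave like 2-chloroethyl, and whether 1H-imidazol-1-yl would keep the result with this carbonyl in place.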